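The compounds below may be only part of what the source reports. "The series", "measured", "known", "first", "only" and "open" are said of these compounds alone.

Working notes on the series.

Of the compounds shown here, three have been measured, all built on a shared core. Compound 1 is `CC1(C)[C@H]2CC[C@]1(C)N(Cc1cn(-c3cccc(F)c3)nn1)C(=O)C2`; compound 2 is `CC1(C)[C@H]2CC[C@]1(C)N(Cc1cn(-c3cccc(C#N)c3)nn1)C(=O)C2`; compound 3 is `CC1(C)[C@H]2CC[C@]1(C)N(Cc1cn(-c3ccccc3O)nn1)C(=O)C2`. In a functional assay on PANC-1 cells (Homo sapiens) for inhibition, read by MTT assay, with a stated time of 24 h (on this read-out lower numbers stand for stronger inhibition and higher numbers for weaker inhibition), compound 1 gives 220 nM. In the same assay compound 2 gives 260 nM, and compound 3 gives 230 nM. The three numbers sit close together: a 1.2-fold higher number from compound 1 to compound 2 (0.07 log units; within the scatter), a 1.0-fold higher number from compound 1 to compound 3 (0.02 log units; within the scatter) and a 1.1-fold lower number from compound 2 to compound 3 (0.05 log units; within the scatter) are all inside the scatter of this assay. Compound 1 has the lowest number of the three, but its nearest neighbours lie within the scatter of it, so no ranking among them can be drawn.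

Compound 4 is `CC1(C)[C@H]2CC[C@]1(C)N(Cc1cn(-c3cccc(O)c3)nn1)C(=O)C2`. Relative to compound 1 the change is hydroxy in place of fluoro on an aromatic carbon. For the measured compounds named here, two measured steps bear on it: the swap of a group at the same aromatic carbon, from compound 1 to compound 2, and the introduction of a hydroxy on the same ring, from compound 1 to compound 3, both within the scatter. No step beyond the scatter is therefore expected in this assay, and the estimated step is a 1.0-fold higher number from compound 1 to compound 4 (0.02 log units; within the scatter). Compound 4 is expected to give 230 nM, with a range of 120 nM to 450 nM.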

Compound 4, half-maximal inhibitory concentration: 280 nM
For compound 4 the middle estimate is 1.2-fold (0.09 log units) below the measured one, within the range that was stated.
By their numbers in this assay, from the lowest: compounds 1, 3, 2 and 4 (each within the scatter of the next).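

In this assay, hydroxy in place of fluoro on this aromatic carbon, meta to a large group, gives a step within the scatter (a 1.3-fold higher number from compound 1 to compound 4 (0.10 log units; within the scatter)), even though hydroxy counts a hydrogen-bond donor and acceptor where fluoro counts neither. Hydroxy also stays within the scatter when set against cyano on the same carbon (a 1.1-fold higher number from compound 2 to compound 4 (0.03 log units; within the scatter)) and when 3-hydroxyphenyl stands in place of 2-hydroxyphenyl (a 1.2-fold higher number from compound 3 to compound 4 (0.09 log units; within the scatter)), so fluoro, cyano and hydroxy at this carbon are not separated, nor are these two hydroxyphenyl groups. No evidence is available to explain why these numbers stay together.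

Still open, on these data alone, is whether an amine, a carboxylic acid or a longer chain such as butoxy on this carbon would give a step beyond the scatter. The compounds shown also leave open how the unsubstituted phenyl group compares with these substituted rings.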